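Ring Nitrogen Substituent Swap in the Amide Series

This account rests on a few compounds, and the source may have more. Where it says the series, first, only, none or still open, it means among the compounds named here.

Compound 1 `Cn1c(-c2ccc(NC(=O)CSc3nc4ccccc4s3)cc2)nc(-c2ccccc2)c1-c1ccccc1` gives 82.7% in a functional assay on HT-29 cells (Homo sapiens) for cytotoxicity, read by MTT assay, with a stated time of 24 h, tested at 80 ug/mL; a higher number here means a stronger effect of the compound at the concentration tested, a lower number a weaker effect. Compound 2 `CN(C)/C=C/N1CCN(CC(=O)Nc2ccc(-c3nc(-c4ccccc4)c(-c4ccccc4)n3C)cc2)CC1` gives 45.4% in this assay, the lowest of the two numbers, with compound 1 the nearest and higher. Within the data shown here, the sole measured step, a number 37.3 percentage points lower from compound 1 to compound 2 (beyond the scatter), exchanges the whole group on the chain carbon and so offers no direct guide to a change made further out on the ring nitrogen. Compound 3 `Cn1c(-c2ccc(NC(=O)CN3CCN(Cc4ccc(Cl)cc4)CC3)cc2)nc(-c2ccccc2)c1-c1ccccc1` differs from compound 2 by 4-chlorobenzyl in place of 2-(dimethylamino)ethenyl on an amine nitrogen in a ring. Among the measured compounds shown here, with no step bearing on this position, a modest rise is expected, a number 9.6 percentage points higher from compound 2 to compound 3 (within the scatter), within wide bounds. Compound 3 is estimated at 55%, between 35% and 75%.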

Compound 3, a percentage reported as activity, at one concentration (the size of the read-out at that concentration, not a potency): 60.7%
The estimate for compound 3 lay 5.7 percentage points below the measured number; measured number inside the range.
By their numbers in this assay, from the lowest: compound 2; then compound 3; then compound 1.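

On the amine nitrogen in the ring, 4-chlorobenzyl in place of 2-(dimethylamino)ethenyl comes with a number 15.3 percentage points higher from compound 2 to compound 3 (beyond the scatter) in this assay. Among these compounds, this is the first sign that the group at this position, with the rest of the structure held fixed, alters the read-out. The change adds one six-membered aromatic ring of carbon only and a chlorine and removes a double bond outside aromatic rings, but nothing available connects the difference to either feature. From the compounds shown here alone, whether benzyl without the chlorine or a simple ethyl on this nitrogen would give a similar number remains open.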